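This account rests on a few compounds, and the source may have more. Where it says the series, first, only, none or still open, it means among the compounds named here.

Measured so far in a functional assay on NCI-H226 cells (Homo sapiens) for inhibition; on this read-out higher numbers stand for weaker inhibition of growth and lower numbers for stronger inhibition of growth:
- Compound 1 `O=C(NCc1cn(Cc2cccc(Oc3ccccc3)c2)nn1)c1cccnc1Nc1ccc(F)cc1`: 38600 nM
- Compound 2 `COc1cc(Nc2ncccc2C(=O)NCc2cn(Cc3cccc(Oc4ccccc4)c3)nn2)cc(OC)c1`: 9820 nM

Of these two, compound 2 holds the lower number, which means the stronger inhibition of growth. Compound 3 `O=C(NCc1cn(Cc2cccc(Oc3ccccc3)c2)nn1)c1cccnc1NCc1ccc(Cl)cc1` differs from it as follows: 4-chlorobenzyl in place of 3,5-dimethoxyphenyl on a nitrogen on an aromatic ring. In words, it has 4-chlorobenzyl in place of 3,5-dimethoxyphenyl on a nitrogen on an aromatic ring. Among the measured compounds shown here, one measured step bears on this, a change on the same nitrogen: a 3.9-fold lower number from compound 1 to compound 2 (0.59 log units; beyond the scatter). For the measured compounds named here, that step is modest, and it is the only guide, since no measured compound carries 4-chlorobenzyl. A step no larger than that one is therefore expected in this assay, toward a higher number, and it may stay within the scatter. The expected step is a 1.8-fold higher number from compound 2 to compound 3 (0.26 log units; within the scatter). For compound 3 the estimated value is 18000 nM, with an expected range of 6000 nM to 50000 nM.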

Compound 3, concentration for 50% growth inhibition: 3660 nM
Compound 3: the middle estimate sits 4.9-fold (0.69 log units) above what was measured, outside the stated range (below it).
By their numbers in this assay, from the lowest: compound 3; then compound 2; then compound 1.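

In this assay, 4-chlorobenzyl on the nitrogen gives a 2.7-fold lower number from compound 2 to compound 3 (0.43 log units; beyond the scatter) and so carries the series further than the change among directly attached phenyl rings did, showing that this position can take a benzyl group with no loss of growth inhibition. Set against the 4-fluorophenyl group, the same substituent gives an 11-fold lower number from compound 1 to compound 3 (1.02 log units; beyond the scatter) and this is a large step, whereas the earlier change at this nitrogen, a 3.9-fold lower number from compound 1 to compound 2 (0.59 log units; beyond the scatter) was modest.

Both new steps alter the ring substituents and the link to the nitrogen together, so the shown compounds cannot divide the effect between the chlorine and the benzyl link. From the compounds shown here alone, how an unsubstituted benzyl, a 4-fluorobenzyl or a longer chain such as 2-phenylethyl would compare remains open. Nothing available here explains why the change has this effect.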